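The compounds below may be only part of what the source reports. "The series", "measured", "known", "first", "only" and "open" are said of these compounds alone.

Measured in an assay on HEK293 cells for antagonist activity at transient receptor potential cation channel subfamily V member 2 (Rattus norvegicus), read by fluorescence and calcium flux, with a stated time of 5 min; a lower number here means a stronger inhibitor, a higher number a weaker inhibitor:
compound 1 `CCCCCCCC/C=C\CCCCCCCC[Se]C[C@H](N)C(=O)NCc1ccc(O)c(OC)c1` gives 1700 nM
compound 2 `CCCCCCCCCCCCCCCCCC(=O)NCc1ccc(O)c(OC)c1` gives > 10000 nM

For compound 2 the value is a limit of this assay, not a number: its result sits at the limit of > 10000 nM in this assay, at which 1 of the 2 values shown sits. Compound 3 `CCCCCCCCCCCCCCCCCCCC(=O)NCc1ccc(O)c(OC)c1` differs from compound 2 by ethyl in place of hydrogen on a saturated chain carbon, ten or more bonds along the chain from a carbonyl carbon. Going by the values given here, with only two compounds measured, no step between a measured pair is available, so no expectation beyond the usual scatter of this assay can be grounded. The step from compound 2 to compound 3 is expected to be a step that the limit leaves unreadable from compound 2 to compound 3, that is, none beyond the scatter. Compound 3 is therefore estimated at 15000 nM, with a range from 5000 nM to 50000 nM, most likely again reported as a limit.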

Compound 3, half-maximal inhibitory concentration: 3100 nM
The estimate for compound 3 lay 4.8-fold (0.68 log units) above the measured number, outside the stated range (below it).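

Ethyl in place of hydrogen on a saturated chain carbon gives an at least 3.2-fold lower number from compound 2 to compound 3 (0.50 log units; beyond the scatter) in this assay. The value of compound 2, > 10000 nM, is a limit of the assay and not a number. Even so, the step shows that a small change this far along the chain can move the result beyond the scatter, which no earlier pair could show.

As far as these compounds go, whether a longer chain would lower the number again stays open, as does the effect of an amine or a carboxylic acid at this same place.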